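Lengthening the Hydrazone Chain of Compound 2

This account rests on a few compounds, and the source may have more. Where it says the series, first, only, none or still open, it means among the compounds named here.

Compound 1, `CC(C)=NNc1nc(-c2cccc([N+](=O)[O-])c2)cs1`, in a functional assay, with a stated time of 30 min; on this read-out lower numbers stand for an effect already at smaller amounts and higher numbers for an effect only at larger amounts of compound: 510000 nM
Compound 2, `C/C(CC(C)C)=N/Nc1nc(-c2cccc([N+](=O)[O-])c2)cs1`, in this assay: 570000 nM

Compound 2 stands alongside compound 1, the two within the scatter of each other: a 1.1-fold higher number from compound 1 to compound 2 (0.05 log units; within the scatter). Compound 3, `CCCCCC/C(C)=N\Nc1nc(-c2cccc([N+](=O)[O-])c2)cs1`, differs from compound 2 by pentyl in place of isopropyl on a saturated chain carbon bound to a carbon with a double bond to nitrogen. Among the measured compounds shown here, the only measured step at that place, a 1.1-fold higher number from compound 1 to compound 2 (0.05 log units; within the scatter), left the read-out essentially unchanged, so the expected step is small: a 1.0-fold lower number from compound 2 to compound 3 (0.02 log units; within the scatter). Compound 3 is therefore expected to give about 550000 nM in this assay, estimated between 250000 nM and 1200000 nM.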

Compound 3, half-maximal effective concentration: 530000 nM
Compound 3: middle estimate off by 1.0-fold (0.02 log units), on the high side, and the stated range covers the measured number.
By their numbers in this assay, from the lowest: compounds 1, 3 and 2 (each within the scatter of the next).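

Pentyl in place of isopropyl on this saturated chain carbon gives a 1.1-fold lower number from compound 2 to compound 3 (0.03 log units; within the scatter) in this assay, and pentyl in place of hydrogen gives a 1.0-fold higher number from compound 1 to compound 3 (0.02 log units; within the scatter). Isopropyl alone had left open what a different chain would do; now pentyl, too, stays within the scatter of the other two compounds. No measurement shown offers a reason for this. On these data alone, whether an amine, a carboxylic acid or a chain longer than pentyl at this place would move the number stays open, as does whether any such change would hold on a different core.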